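This account rests on a few compounds, and the source may have more. Where it says the series, first, only, none or still open, it means among the compounds named here.

Among the compounds with values here, compound 2, `CCCC(=O)c1ccn(-c2ccc3c(c2)B(O)OC3)c1`, is one of two compounds so far measured in an ADME assay on L929 cells (Mus musculus) for cytotoxicity, read by resazurin assay, with a stated time of 72 h; on this read-out higher numbers stand for weaker inhibition and lower numbers for stronger inhibition. In this assay compound 2 gives only a limit, > 10 ug/mL. Its nearest relative is compound 1, `CC(=O)c1ccn(-c2ccc3c(c2)B(O)OC3)c1`. In this assay compound 1 likewise gives only a limit, > 10 ug/mL. The step from compound 1 to compound 2, ethyl in place of hydrogen on a saturated chain carbon bound to a carbonyl carbon, is a step that the two limits leave unreadable from compound 1 to compound 2. Within the data shown here, both readings sit at the limit of > 10 ug/mL in this assay, at which 2 of the 2 values shown sit, so no step of known size is in hand.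

Compound 3, `Cc1ccsc1C(=O)c1ccn(-c2ccc3c(c2)B(O)OC3)c1`, has not yet been measured in this assay. It differs from compound 2 by 3-methylthiophen-2-yl in place of propyl on a carbonyl carbon. Among the measured compounds shown here, the only measured step, from compound 1 to compound 2, was hidden by its two limits, so it gives no guide to how large the change to compound 3 should be, or in which direction. With both neighbours resting at the limit, the plain expectation for compound 3 is that it also stays at or close to that limit. Compound 3 is therefore estimated at 15 ug/mL, with a likely range from 5 ug/mL to 40 ug/mL. In this assay the expected step is a step that the limit leaves unreadable from compound 2 to compound 3.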

Compound 3, half-maximal inhibitory concentration: > 10 ug/mL
Compound 3 gave a limit, no number; the forecaster's own chance of this, stated with the estimate: 70%; the middle value does not contradict the limit.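

No step among compound 1, compound 2 and compound 3 can be read in this assay, since each gives a limit rather than a number: the limit of > 10 ug/mL in this assay, at which 3 of the 3 values shown sit.

The compounds shown leave open how far each one's true value lies from that limit, and whether swapping the group on the carbonyl carbon changes the read-out at all.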